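The compounds below may be only part of what the source reports. "The series", "measured", "known", "first", "only" and "open" are said of these compounds alone.

Measured in an assay on HEK293 cells for inhibition of Fatty-acid amide hydrolase 1 (Homo sapiens), read by fluorescence; on this read-out higher numbers stand for weaker inhibition and lower numbers for stronger inhibition:
compound 1, `COc1ccc(-c2ccc3oc(NC4CCCCC4)nc3c2)cc1C`: 228 nM
compound 2, `N#Cc1cc(-c2ccc3oc(NC4CCCCC4)nc3c2)ccc1O`: 54 nM
compound 3, `Cn1ccc2cc(-c3ccc4oc(NC5CCCCC5)nc4c3)ccc21`: 911 nM

Compound 3 gives the highest of the three numbers in this assay. Compound 1 stands nearest to it, its number lower by a margin beyond the usual scatter; compound 2 stands furthest, lower still. For the measured compounds named here, no pair among the three differs in a single place, so no step between measured compounds can be read off; the compounds differ in more than one place and their values can only be set side by side.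

Compound 4, `Cn1ccc2cc(-c3ccc4oc(N5CCNCC5)nc4c3)ccc21`, has not been measured in this assay. It differs from compound 3 in one place: piperazin-1-yl in place of cyclohexylamino on an aromatic carbon. The cyclohexylamino group is shared by all three measured compounds, so nothing measured here speaks to its replacement, and the expectation has no measured anchor. Since compound 3 already gives 911 nM and so the highest number of the set, the expectation is a further move in the same direction, a step of moderate size toward weaker inhibition, though a step of no size beyond the scatter cannot be ruled out. The expected step is a 3.3-fold higher number from compound 3 to compound 4 (0.52 log units; beyond the scatter). Compound 4 is expected to give 3000 nM, with a range from 800 nM to 12000 nM, and some chance that only a limit is returned.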

Compound 4, half-maximal inhibitory concentration: > 1000 nM
Compound 4: only a limit was reported; the forecaster's own chance of this, stated with the estimate: 25%; the middle value does not contradict the limit.
By their numbers in this assay, from the lowest: compound 2; then compound 1; then compound 3. At a limit, above all of these: compound 4.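

In this assay compound 4 gives > 1000 nM, which is a limit and not a number. Piperazin-1-yl in place of cyclohexylamino, on the aromatic carbon next to the ring nitrogen and next to the ring oxygen, is the first change at this position among the compounds shown, and it can be read only as a floor, an at least 1.0-fold higher number from compound 3 to compound 4 (0.04 log units; that floor lies within the scatter); the true size of the step stays unread, and a step within the scatter cannot be told from a large loss of inhibition: the limit of > 1000 nM in this assay, at which 1 of the 4 values shown sits. What the result does show is that piperazin-1-yl at this position gives no sign of stronger inhibition than cyclohexylamino on the core of compound 3.

Still open, from the compounds shown here alone, is whether the same replacement would read the same way on the cores of compound 1 and compound 2, which keep cyclohexylamino and give lower numbers than compound 3. Also open, going by these compounds, is how this position would respond to other groups, such as an open-chain amine like dimethylamino, a smaller ring like pyrrolidin-1-yl, or a longer alkyl chain on the amine nitrogen.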